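A few compounds are considered here, and "the series" means these few. Any claim that something is new, unique, unknown or untested is made for them only; others in the source may bear on it.

Among the compounds with values here, the three compounds measured so far share one core. Compound 1 is `COc1ccc(-c2cnc(NC(=O)c3cccc(OC)c3)n2C)cc1`, compound 2 is `COc1ccc(-c2cnc(NC(=O)c3cccc(C#N)c3)n2C)cc1` and compound 3 is `CCCC(=O)Nc1ncc(-c2ccc(OC)cc2)n1C`. In a toxicity assay on THP-1 cells (Homo sapiens) for inhibition (on this read-out lower numbers stand for higher toxicity in this test and higher numbers for lower toxicity in this test), compound 1 gives no number but only a limit of the assay, > 100000 nM. Compound 2 likewise reaches only the limit > 100000 nM in this assay. For compound 3, this assay again records only the limit > 100000 nM. Compound 3 thus stands at the edge of what the assay can read, no higher and no lower than its two companions as far as the numbers show. Since all three values sit at the limit of > 100000 nM in this assay, at which 3 of the 3 values shown sit, the steps a step that the two limits leave unreadable from compound 1 to compound 2, a step that the two limits leave unreadable from compound 1 to compound 3 and a step that the two limits leave unreadable from compound 2 to compound 3 cannot be read in size.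

Compound 4, not yet measured, is `COc1ccc(-c2cnc(NC(=O)c3ccccc3O)n2C)cc1`. It differs from compound 3 by 2-hydroxyphenyl in place of propyl on a carbonyl carbon. Within the data shown here, the steps that bear on this change are those at the same carbonyl carbon, a step that the two limits leave unreadable from compound 1 to compound 3 and a step that the two limits leave unreadable from compound 2 to compound 3, and both are unreadable; they give no hint of any step beyond the scatter in this assay. Compound 4 is therefore expected to give about 150000 nM in this assay, within a range from 50000 nM to 500000 nM. The expected step that the limit leaves unreadable from compound 3 to compound 4 amounts to nothing beyond the scatter, most likely another limit.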

Compound 4, half-maximal cytotoxic concentration: > 100000 nM
Compound 4 gave a limit, no number (the forecaster's own chance of this, stated with the estimate: 80%); the middle value lies beyond the limit too.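

No step between compound 4 and compound 1, compound 2 or compound 3 can be read in size, because every value stands at the same assay limit: the limit of > 100000 nM in this assay, at which 4 of the 4 values shown sit.

The compounds shown leave open whether any group on the carbonyl carbon changes the read-out in this assay, and where any of these four compounds would give an actual number.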